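The source may report more compounds than this note shows. Statements on the series, on what has been measured and on what is new or still open speak of the compounds shown alone.

The shared core is carried by compound 1 `Cc1ccccc1CN1CCC(O)(Cn2cnc3c(cnn3-c3ccc(F)cc3)c2=O)CC1`, compound 2 `COC(=O)c1ccc(CN2CCC(O)(Cn3cnc4c(cnn4-c4ccc(F)cc4)c3=O)CC2)cc1` and compound 3 `O=c1c2cnn(-c3ccc(F)cc3)c2ncn1CC1(O)CCN(Cc2c(Cl)cccc2Cl)CC1`. In an assay on Sf21 cells for inhibition of ubiquitin carboxyl-terminal hydrolase 7 (Homo sapiens), read by spectrophotometry, with stated times of 30 min and 2 h (on this read-out lower numbers stand for stronger inhibition and higher numbers for weaker inhibition), compound 2 gives 4500 nM. For compound 1 the entry in this assay reads "not determined" (no result reported). Compound 3 likewise stands at "not determined" (no result reported) in this assay, so there is nothing on this read-out to set it against compound 2. Compound 4 `O=c1c2cnn(-c3ccc(F)cc3)c2ncn1CC1(O)CCN(Cc2ccc(F)cc2Cl)CC1` differs from compound 3 by 2-chloro-4-fluorophenyl in place of 2,6-dichlorophenyl on a saturated chain carbon bound to an amine nitrogen in a ring. Among the compounds with values here, no measured step of this kind is in hand, so the size and direction of the change in this assay cannot be read from the data; a shift no larger than the scatter seems as plausible as any other outcome. Compound 4 is therefore expected to land near 3000 nM, within 600 nM to 15000 nM. Within the data shown here, that expectation leans only on compound 2, whose value 4500 nM is the sole number available.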

Compound 4, half-maximal inhibitory concentration: 1600 nM
Compound 4: the middle estimate sits 1.9-fold (0.27 log units) above what was measured, and the stated range covers the measured number.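

In this assay, the group on a saturated chain carbon bound to an amine nitrogen in a ring now shows a measurable effect on the number: 2-chloro-4-fluorophenyl in place of 4-(methoxycarbonyl)phenyl gives a 2.8-fold lower number from compound 2 to compound 4 (0.45 log units; beyond the scatter), a modest shift. The step from 2,6-dichlorophenyl cannot be read, as compound 3 has no number. Nothing on hand accounts for the shift. From the compounds shown here alone, it remains open how a benzyl group carrying an amine or a carboxylic acid, or a longer chain at this place, would read.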